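Three measured aryl variants and a quinolinyl newcomer

A few compounds are considered here, and "the series" means these few. Any claim that something is new, unique, unknown or untested is made for them only; others in the source may bear on it.

The measured compounds:
- Compound 1 `COc1ccc(-c2c3ccc4ccccc4c3nc3c2c(C)nc2c4ccccc4ccc32)cc1` gives 176 ug/mL in a functional assay, with a stated time of 90 s; a higher number here means a weaker inhibitor, a lower number a stronger inhibitor.
- Compound 2 `Cc1nc2c3ccccc3ccc2c2nc3c(ccc4ccccc43)c(-c3ccccc3N)c12` gives 125 ug/mL in this assay.
- Compound 3 `Cc1nc2c3ccccc3ccc2c2nc3c(ccc4ccccc43)c(-c3ccccc3Cl)c12` gives 170 ug/mL in this assay.

All three share one core and differ only in the aryl group carried on it. Compound 3 stands second highest of the three numbers, but the spread is slight: its nearest neighbour is compound 1, and its furthest is compound 2, with a 1.4-fold higher number from compound 2 to compound 3 (0.13 log units; within the scatter) and a 1.0-fold lower number from compound 1 to compound 3 (0.02 log units; within the scatter) both within the scatter. The remaining comparison, a 1.4-fold lower number from compound 1 to compound 2 (0.15 log units; within the scatter), is likewise within the scatter, so no measured exchange of the aryl group has moved the read-out.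

Compound 4 `Cc1nc2c3ccccc3ccc2c2nc3c(ccc4ccccc43)c(-c3cc(O)nc4ccccc34)c12` has not yet been measured. It differs from compound 3 by 2-hydroxyquinolin-4-yl in place of 2-chlorophenyl on an aromatic carbon. None of the measured steps involves a 2-hydroxyquinolin-4-yl group, so the steps bearing on it are only those just named, which show that swapping the aryl group among these three leaves the number unchanged. A step of no more than the scatter is therefore expected for a 1.1-fold lower number from compound 3 to compound 4 (0.05 log units; within the scatter), in no particular direction, with a wide range to allow for the untested group. Compound 4 is estimated at 150 ug/mL, between 60 ug/mL and 400 ug/mL.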

Compound 4, half-maximal inhibitory concentration: 148 ug/mL
Estimate against measurement, compound 4: 1.0-fold (0.01 log units) above; the range from low to high includes it.
By their numbers in this assay, from the lowest: compounds 2, 4, 3 and 1 (each within the scatter of the next).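

In this assay, the position opposite the ring nitrogen now carries a fused two-ring group rather than a single ring: 2-hydroxyquinolin-4-yl, with 11 heavy atoms, 1 hydrogen-bond donor and 2 hydrogen-bond acceptors, replaces 2-chlorophenyl, with 7 heavy atoms and neither donors nor acceptors, and the result is a 1.1-fold lower number from compound 3 to compound 4 (0.06 log units; within the scatter) and no real change. Within the data shown here, the comparisons with the other two aryl groups agree, giving a 1.2-fold higher number from compound 2 to compound 4 (0.07 log units; within the scatter) and a 1.2-fold lower number from compound 1 to compound 4 (0.08 log units; within the scatter), so the insensitivity seen among the single-ring aryl groups of the earlier compounds now extends, for these four compounds, to a larger group with a ring nitrogen and a hydroxyl. No supporting measurement is available to explain why the read-out stays flat across these groups.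

From the compounds shown here alone, all four compounds carry an aromatic ring at this position, so it remains open whether a non-aromatic group, such as a small alkyl chain, an aliphatic amine or a carboxylic acid, would move the number. The methyl group on the shared core stays constant throughout, so what a change there would do is also unknown.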